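The compounds below may be only part of what the source reports. "The series", "measured", "known", "first", "only" and "open" are said of these compounds alone.

In this assay a functional assay on CHO cells for agonist activity at Melanocortin receptor 4 (Homo sapiens), read by cAMP accumulation (a higher number here means that more compound is needed for the effect, a lower number that less compound is needed), three compounds have been measured. Compound 1 `CCC(=O)N1C[C@@H](C(=O)N2CCN(c3ccc(C)cc3[C@@H](NC(=O)CCN(C)C)C(C)C)CC2)[C@H](c2ccc(Cl)cc2)C1` gives 27 nM, compound 2 `CC(=O)N1C[C@@H](C(=O)N2CCN(c3ccc(C)cc3[C@@H](NC(=O)CCN(C)C)C(C)C)CC2)[C@H](c2ccc(Cl)cc2)C1` gives 44 nM, and compound 3 `CC(C)[C@H](NC(=O)CCN(C)C)c1cccc(F)c1N1CCN(C(=O)[C@@H]2CN(C(C)C)C[C@H]2c2ccc(Cl)cc2)CC1` gives 20 nM. Compound 3 stands at the low end of these numbers: its gap to compound 1 is within the usual scatter, its gap to compound 2 beyond it.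

Compound 4 `CC(C)[C@H](NC(=O)CCN(C)C)c1cccc(F)c1N1CCN(C(=O)[C@@H]2CN(C(C)C)C[C@H]2c2ccc(F)c(Cl)c2)CC1` differs from compound 3 in one place: 3-chloro-4-fluorophenyl in place of 4-chlorophenyl on a saturated ring carbon. Going by the values given here, the single measured step, a 1.6-fold higher number from compound 1 to compound 2 (0.21 log units; within the scatter), concerns the acyl group on the ring nitrogen and so touches a different part of the molecule; no measured pair changes the aryl group on the saturated ring carbon. Among the compounds with values here, there is thus no direct precedent for this change, and the one recorded step being small suggests that modest edits leave this assay largely unmoved. Compound 4 is therefore expected to show no step beyond the scatter, a 1.1-fold lower number from compound 3 to compound 4 (0.05 log units; within the scatter). The estimate for compound 4 is 18 nM, with a range from 7 nM to 45 nM.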

Compound 4, half-maximal effective concentration: 410 nM
The estimate for compound 4 lay 23-fold (1.36 log units) below the measured number, and the stated range ends below it.
By their numbers in this assay, from the lowest: compounds 3, 1 and 2 (each within the scatter of the next, the first and the last beyond it); then compound 4.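

In this assay the aryl group on the saturated ring carbon turns out to matter strongly: 3-chloro-4-fluorophenyl in place of 4-chlorophenyl gives a 21-fold higher number from compound 3 to compound 4 (1.31 log units; beyond the scatter) in a single exchange. Going by these compounds alone, the only earlier step, a 1.6-fold higher number from compound 1 to compound 2 (0.21 log units; within the scatter) at the acyl group on the ring nitrogen, gave no sign of a change this large. The two groups have the same counts of hydrogen-bond donors, hydrogen-bond acceptors and net charge, so the step arises with those counts unchanged, and no measurement at hand accounts for it.

Which part of the new substitution carries the step stays open, and so does how 3-chlorophenyl or 4-fluorophenyl alone would read. Also open, going by these compounds, is whether the same exchange would move the acylated compounds 1 and 2 as far, and how an aryl group bearing an amine would behave here.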